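The compounds below may be only part of what the source reports. "The series", "measured", "known", "first", "only" and "open" are said of these compounds alone.

Measured in an ADME assay on HepG2 2.2.15 cells (Homo sapiens) for cytotoxicity, read by MTT assay; a higher number here means that more compound is tolerated, a lower number that less compound is tolerated:
- Compound 1 `C=C1CC[C@@H]2[C@](C)(COC(=O)c3cccnc3)[C@H](O)CC[C@@]2(C)[C@@H]1/C=C/C1=CCOC1=O`: 113000 nM
- Compound 2 `C=C1CC[C@@H]2[C@](C)(COC(=O)c3ccccc3C(=O)O)[C@H](OC(=O)c3ccccc3C(=O)O)CC[C@@]2(C)[C@@H]1/C=C/C1=CCOC1=O`: > 1620000 nM (a limit of the assay)
- Compound 3 `C=C1CC[C@@H]2[C@](C)(COC(=O)c3cccnc3)[C@H](O)CC[C@@]2(C)[C@@H]1C/C=C1\C=COC1=O`: 2050000 nM

Of the two exact numbers, the higher belongs to compound 3, at 2050000 nM. The result for compound 2 is only a limit and gives no exact number.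

Compound 4 `C=C1CC[C@@H]2[C@](C)(COC(C)=O)[C@H](O)CC[C@@]2(C)[C@@H]1C/C=C1\C=COC1=O` differs from compound 3 by having methyl in place of pyridin-3-yl on a carbonyl carbon, so that (pyridin-3-yl)carbonyl becomes acetyl. Going by the values given here, only one step has been measured between compounds that differ in one place: an 18-fold higher number from compound 1 to compound 3 (1.26 log units; beyond the scatter). That step is large, but it lies on a saturated ring carbon and leaves this ester unchanged, so it bears on the new change only indirectly. Compound 2 differs from compound 3 in more than one place. Among the compounds with values here, with no measured step at this ester, no large shift in this assay is expected, and no direction is firmly indicated. The expected change is a 1.7-fold lower number from compound 3 to compound 4 (0.23 log units; within the scatter), which would lie within the scatter. The estimated value for compound 4 is 1200000 nM, with an expected range of 350000 nM to 3500000 nM.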

Compound 4, half-maximal cytotoxic concentration: 334000 nM
Estimate against measurement, compound 4: 3.6-fold (0.56 log units) above, and the stated range ends above it.
By their numbers in this assay, from the lowest: compound 1; then compound 4; then compound 3.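

Exchanging pyridin-3-yl for methyl on the carbonyl carbon gives a 6.1-fold lower number from compound 3 to compound 4 (0.79 log units; beyond the scatter) in this assay, so this ester is itself a place where the number moves beyond the scatter, which the earlier step at the saturated ring carbon could not show, as it left the ester unchanged. The direction is known for this single pair only, and one pair sets no trend across groups at this ester. No measured property among the data shown accounts for the shift.

The compounds shown leave open whether a phenyl ring or a longer chain such as butanoyl on this carbonyl carbon would give a number closer to that of compound 3 or to that of compound 4. They also leave open whether the same exchange would shift the number in the same direction on the core of compound 1.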